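The source may hold more compounds than are shown below. What is called first, only, known or untested is meant among the compounds shown, and "the series" means these compounds.

Measured compounds in an assay on isolated protein for antagonist activity at Bile acid receptor (Homo sapiens), read by TR-FRET and LanthaScreen; on this read-out higher numbers stand for weaker inhibition and lower numbers for stronger inhibition:
compound 1 `Cc1ccc2nc([C@H](CC3CCNCC3)N3C(=O)CN(c4ccc(Oc5ccccc5)cc4)C3=O)n(C)c2c1` gives 64000 nM;
compound 2 `Cc1ccc2nc([C@H](CC3CCN(C(=O)C(C)C)CC3)N3C(=O)CN(c4ccc(Oc5ccccc5)cc4)C3=O)n(C)c2c1` gives 35 nM;
compound 3 `Cc1ccc2nc([C@H](CC3CCN(C(=O)C4CCCC4)CC3)N3C(=O)CN(c4ccc(Oc5ccccc5)cc4)C3=O)n(C)c2c1` gives 30 nM.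

Compound 2 and compound 3 cannot be told apart on these numbers: the step of a 1.2-fold lower number from compound 2 to compound 3 (0.07 log units; within the scatter) lies within the scatter. Compound 1 stands far from both. The steps of a 1800-fold lower number from compound 1 to compound 2 (3.26 log units; beyond the scatter) and a 2100-fold lower number from compound 1 to compound 3 (3.33 log units; beyond the scatter) are both large, and both concern the acyl group on the ring amine nitrogen, which compound 2 and compound 4 share unchanged.

Compound 4 `CC(C)C(=O)N1CCC(C[C@@H](c2nc3ccccc3n2C)N2C(=O)CN(c3ccc(Oc4ccccc4)cc3)C2=O)CC1` differs from compound 2 in another place: hydrogen in place of methyl on an aromatic carbon. Going by the values given here, none of the measured steps touches this ring, so the data give no direct guide to this change in this assay. The measured steps that leave the acylated amine in place stay within the scatter, and a small change at an aromatic carbon is most plausibly read the same way. Compound 4 is therefore expected to give a number close to that of compound 2, with the step of a 1.4-fold higher number from compound 2 to compound 4 (0.15 log units; within the scatter) expected to stay within the scatter. The estimate for compound 4 in this assay is 50 nM, with a range from 15 nM to 170 nM.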

Compound 4, half-maximal inhibitory concentration: 38 nM
Estimate against measurement, compound 4: 1.3-fold (0.12 log units) above, within the range that was stated.
By their numbers in this assay, from the lowest: compounds 3, 2 and 4 (each within the scatter of the next); then compound 1.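

In this assay, replacing methyl with hydrogen on the aromatic carbon gives a 1.1-fold higher number from compound 2 to compound 4 (0.04 log units; within the scatter), so the change from 1,6-dimethyl-1H-benzimidazol-2-yl to 1-methyl-1H-benzimidazol-2-yl leaves no difference that this read-out can resolve. Going by these compounds alone, this is the first measured step at this six-membered aromatic ring, and it shows that, with the isopropylcarbonyl group kept on the ring amine nitrogen, the methyl is not needed to hold the number at the level of compound 2. No evidence is available to explain this result.

The compounds shown leave open how other groups on this aromatic carbon, such as a chlorine atom, methoxy or a carboxylic acid, would read. They also leave open whether hydrogen at this carbon would read the same alongside the cyclopentylcarbonyl group of compound 3.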